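Working notes: from compound 3 to compound 4

A few compounds are considered here, and "the series" means these few. Any claim that something is new, unique, unknown or untested is made for them only; others in the source may bear on it.

Measured so far in an ADME assay on the whole organism for pharmacokinetics, with Rattus norvegicus as the target, at a dose of 5 mg/kg by the oral route (on this read-out higher numbers stand for higher exposure at the dose given and lower numbers for lower exposure), for this series:
- compound 1 `COCCN1C(=O)CNc2ncc(-c3ccc(C(C)(C)O)nc3)nc21` gives 5600 nM
- compound 2 `CO[C@H]1CC[C@@H](N2CC(=O)Nc3ncc(-c4ccc(C(C)(C)O)nc4)nc32)CC1` gives 2770 nM
- compound 3 `CO[C@H]1CC[C@H](CN2CC(=O)Nc3ncc(-c4ccc(C(C)(C)O)nc4)nc32)CC1` gives 700 nM

Compound 3 stands lowest of the three in this assay and its gaps to compound 2 and to compound 1 both lie beyond the scatter. Compound 4 `CO[C@H]1CC[C@H](N2CC(=O)Nc3ncc(-c4ccc(C(C)(C)O)nc4)nc32)CC1` is still to be measured. The change from compound 3 is 4-methoxycyclohexyl in place of (4-methoxycyclohexyl)methyl on a nitrogen on an aromatic ring in a ring and it puts 4-methoxycyclohexyl in place of (4-methoxycyclohexyl)methyl on a nitrogen on an aromatic ring in a ring.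

Among the compounds with values here, one measured step bears on this: a 4.0-fold lower number from compound 2 to compound 3 (0.60 log units; beyond the scatter), modest and beyond the scatter, is the same exchange of groups run the other way. Within the data shown here, compound 2 and compound 4 both carry 4-methoxycyclohexyl, but they are drawn with a different arrangement at its defined stereocentres, and no measured pair shows what that difference is worth. A higher number is therefore expected in this assay, of about the size of that one step or somewhat less. The expected step is a 2.9-fold higher number from compound 3 to compound 4 (0.46 log units; beyond the scatter) on this estimate. The estimated value for compound 4 is 2000 nM with an expected range from 700 nM to 6000 nM for this single measurement.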

Compound 4, maximal plasma concentration: 6300 nM
For compound 4 the middle estimate is 3.2-fold (0.50 log units) below the measured one; the whole stated range lies below it.
By their numbers in this assay, from the lowest: compound 3; then compound 2; then compounds 1 and 4 (each within the scatter of the next).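

In this assay, the exchange at the nitrogen on an aromatic ring in a ring now has a direct reading in the direction of the shorter attachment, a 9.0-fold higher number from compound 3 to compound 4 (0.95 log units; beyond the scatter), and it agrees in sign with a 4.0-fold lower number from compound 2 to compound 3 (0.60 log units; beyond the scatter), so both 4-methoxycyclohexyl compounds stand above the (4-methoxycyclohexyl)methyl compound. Within the data shown here, the result also puts a first measured size on the drawn arrangement of 4-methoxycyclohexyl at this position, a 2.3-fold higher number from compound 2 to compound 4 (0.36 log units; beyond the scatter), a step beyond the scatter that the earlier compounds could not give. The step is attributable to configuration alone, with no other structural change available to account for it: the fact that compounds 2 and 4 differ only in the configuration as drawn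

The compounds shown carry (4-methoxycyclohexyl)methyl in a single drawn arrangement, so what configuration is worth on that group stays open. Also open, as far as these compounds go, is how this read-out would respond to an amine or a carboxylic acid in place of the methoxy group on the cyclohexyl ring, and whether the order seen here would hold at another dose or by another route.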